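Swapping Thiophene for Chlorophenyl on a Shared Core

The source may report more compounds than this note shows. Statements on the series, on what has been measured and on what is new or still open speak of the compounds shown alone.

Compound 1 `O=Cc1ccc(-c2cn3ccnc3c(-c3ccc4ncn(C5CCCCC5)c4c3)n2)cc1`: 32%
Compound 2 `c1cn2cc(-c3ccsc3)nc(-c3ccc4ncn(C5CCCCC5)c4c3)c2n1`: 6.09%

In a functional assay on U-251 cells (Homo sapiens) for inhibition, read by sulforhodamine B assay, with a stated time of 48 h, tested at 10 uM (a higher number here means more inhibition at the concentration tested (going by the name of the read-out), a lower number less inhibition), compound 1 gives 32%, while compound 2 gives 6.09%, the lowest of the two numbers, with compound 1 as its nearest neighbour. Compound 3 `Clc1ccc(-c2cn3ccnc3c(-c3ccc4ncn(C5CCCCC5)c4c3)n2)cc1` differs from compound 2 in one place: 4-chlorophenyl in place of thiophen-3-yl on an aromatic carbon. Among the measured compounds shown here, the one measured step, a number 25.9 percentage points lower from compound 1 to compound 2 (beyond the scatter), bears on this change. In that step a six-membered aromatic ring of carbon only gave way to thiophen-3-yl. For the measured compounds named here, the reverse direction is now taken, though with 4-chlorophenyl rather than 4-formylphenyl, a pair for which no step is known. An upward step is therefore expected, but of uncertain size. Compound 3 is estimated at 22%, between 2% and 45%. That expectation amounts to a step of a number 15.9 percentage points higher from compound 2 to compound 3 (beyond the scatter).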

Compound 3, a percentage reported as inhibition, at one concentration (the size of the read-out at that concentration, not a potency): 11.3%
For compound 3 the middle estimate is 10.7 percentage points above the measured one, within the range that was stated.
By their numbers in this assay, from the lowest: compounds 2 and 3 (each within the scatter of the next); then compound 1.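

In this assay the change to a six-membered aromatic ring did not by itself lift the read-out: 4-chlorophenyl in place of thiophen-3-yl gave a number 5.2 percentage points higher from compound 2 to compound 3 (within the scatter). Chloro in place of formyl gave a number 20.7 percentage points lower from compound 1 to compound 3 (beyond the scatter), so among these compounds the higher number goes with the 4-formylphenyl group of compound 1, not with the phenyl ring alone. No supporting data explain this difference.

On these data alone, whether an amine or a carboxylic acid in place of the formyl would match compound 1 remains open.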